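The compounds below may be only part of what the source reports. "The series", "measured", "known", "first", "only" and "open" are said of these compounds alone.

Compound 3 `Cc1ccccc1Nc1nc(SCc2cn(CC(=O)NC(=O)Nc3ccccn3)nn2)nc(-c2ccc(C(C)C)cc2)c1C#N` gives the lowest of the three numbers recorded in a functional assay on ECa-109 cells (Homo sapiens) for inhibition, read by MTT assay, with a stated time of 72 h (a higher number here means a weaker inhibitor, a lower number a stronger inhibitor), where compound 3 gives 7230 nM. Compound 1 `CC(C)c1ccc(-c2nc(SCc3cn(CC(=O)NC(=O)Nc4ccccn4)nn3)nc(Nc3ccc(Cl)cc3)c2C#N)cc1` gives 11200 nM in this assay, and the step of a 1.5-fold lower number from compound 1 to compound 3 (0.19 log units; within the scatter) stays within the scatter. Compound 2 `CC(C)c1ccc(-c2nc(SCc3cn(CC(=O)NC(=O)Nc4ccccn4)nn3)nc(Nc3cccc(C(F)(F)F)c3)c2C#N)cc1` gives 24200 nM in this assay, so the step of a 3.3-fold lower number from compound 2 to compound 3 (0.52 log units; beyond the scatter) reaches beyond it, as does the step of a 2.2-fold higher number from compound 1 to compound 2 (0.33 log units; beyond the scatter).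

Compound 4 `CC(C)c1ccc(-c2nc(SCc3cn(CC(=O)NC(=O)Nc4ccccn4)nn3)nc(Nc3ccccc3O)c2C#N)cc1` differs from compound 3 in one place: hydroxy in place of methyl on an aromatic carbon. All three measured steps alter the same aryl group on the nitrogen, yet none of them exchanges a methyl for a hydroxy, so they bear on this change only loosely; their sizes were modest throughout. Compound 4 is therefore expected to land near compound 3, and the step of a 1.4-fold higher number from compound 3 to compound 4 (0.14 log units; within the scatter) is estimated to be small. Compound 4 is expected to give 10000 nM in this assay, within a range from 4000 nM to 25000 nM.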

Compound 4, half-maximal inhibitory concentration: 7380 nM
Compound 4: the middle estimate sits 1.4-fold (0.13 log units) above what was measured; low and high end bracket the measured number.
By their numbers in this assay, from the lowest: compounds 3, 4 and 1 (each within the scatter of the next); then compound 2.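

In this assay, the step from methyl to hydroxy on an aromatic carbon ortho to a large group is a 1.0-fold higher number from compound 3 to compound 4 (0.01 log units; within the scatter) and so shows no readable difference, even though hydroxy brings a hydrogen-bond donor and a hydrogen-bond acceptor that methyl lacks. The 2-hydroxyphenyl group also relates to the other two aryl groups much as the 2-methylphenyl group does: the step of a 3.3-fold lower number from compound 2 to compound 4 (0.52 log units; beyond the scatter) reaches beyond the scatter, while the step of a 1.5-fold lower number from compound 1 to compound 4 (0.18 log units; within the scatter) stays within it. No measurement is available that bears on this result.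

The compounds shown leave open whether an amine, a methoxy group or a carboxylic acid on this same aromatic carbon would also read like methyl and hydroxy. They also leave open whether a longer chain there would do so.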